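The compounds below may be only part of what the source reports. "The series", "measured", "known", "first", "only" and "open" are said of these compounds alone.

Compound 1 `C=CC[C@H]1C[C@@H]([C@@H](O)c2ccccc2)CO[C@@H]1c1ccccc1` gives 36000 nM in a functional assay on HL-60 cells (Homo sapiens) for cytotoxicity, read by WST assay, with a stated time of 48 h; on this read-out lower numbers stand for stronger inhibition and higher numbers for weaker inhibition. Among the compounds with values here, compound 2 `COc1ccc(/C=C/C[C@@H]2C[C@@H]([C@@H](O)c3ccc(OC)c(OC)c3)CO[C@H]2c2ccc(OC)c(OC)c2)cc1OC` gives 26000 nM in this assay; the two numbers lie within the scatter of each other, and no step between them is drawn. Compound 3 `O[C@@H](c1ccccc1)[C@H]1CO[C@H](c2ccccc2)[C@@H](C/C=C/c2ccccc2F)C1` carries 2-(2-fluorophenyl)ethenyl in place of vinyl on a saturated chain carbon bound to a saturated ring carbon. Because compound 2, with a substituted aromatic ring on its chain, gives 26000 nM, the change in this assay for compound 3 is expected to be small, toward a lower number. The expected step is a 1.8-fold lower number from compound 1 to compound 3 (0.26 log units; within the scatter). Compound 3 is estimated at 20000 nM, with a range from 6000 nM to 60000 nM.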

Compound 3, half-maximal inhibitory concentration: 9530 nM
Beside the measured number, compound 3's estimate is 2.1-fold (0.32 log units) above it, and the stated range covers the measured number.
By their numbers in this assay, from the lowest: compound 3; then compounds 2 and 1 (each within the scatter of the next).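

In this assay, the chain position on the core of compound 1 accepts an aromatic ring: 2-(2-fluorophenyl)ethenyl in place of vinyl gives a 3.8-fold lower number from compound 1 to compound 3 (0.58 log units; beyond the scatter). This is a modest step, but it shows that the number at this position responds to the group carried on the chain. Nothing at hand bears on the cause of the step.

Still open, on these data alone, is whether the step comes with the aromatic ring alone or needs the fluorine, which an unsubstituted phenyl would separate. As far as these compounds go, how an amine on that ring or a longer chain would read is equally open.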